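Shortening the chain from compound 3 to compound 4

This account rests on a few compounds, and the source may have more. Where it says the series, first, only, none or still open, it means among the compounds named here.

Measured in an ADME assay on HEK293 cells (Homo sapiens) for inhibition, read by MTT assay, with stated times of 18 h and 4 h; on this read-out higher numbers stand for weaker inhibition and lower numbers for stronger inhibition:
- compound 1 `CCCCCCCCOP(=O)(O)OCCSC(=S)N1CCCC1` gives 28300 nM
- compound 2 `CCCOP(=O)(O)OCCSC(=S)N1CCCCC1` gives > 100000 nM (a limit)
- compound 3 `CCCCCCCCCCOP(=O)(O)OCCSC(=S)N1CCCC1` gives > 100000 nM (a limit)

Compound 3 stands at a limit of the assay (> 100000 nM), so it gives no number to step from. Compound 2 is likewise a limit (> 100000 nM). Of the values in hand, the common reading is (the limit of > 100000 nM in this assay, at which 2 of the 3 values shown sit), and only compound 1 gives a number (28300 nM).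

Compound 4 (`CCCOP(=O)(O)OCCSC(=S)N1CCCC1`) is the next case, and its change from compound 3 is large (hydrogen in place of heptyl on a saturated chain carbon, three bonds along the chain from an oxygen on an unsaturated carbon): hydrogen in place of heptyl on a saturated chain carbon, three bonds along the chain from an oxygen on an unsaturated carbon.

Among the measured compounds shown here, one measured step bears on this (an at least 3.5-fold higher number from compound 1 to compound 3 (0.54 log units; beyond the scatter)). It is at least modest and beyond the scatter, but it covers only ethyl in place of hydrogen, so it says little about a change of this size. Read backwards, it leaves a lower number in this assay possible, though a single step gives weak support, and the expectation leans towards the limit.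

The expected step is (an at least 1.1-fold lower number from compound 3 to compound 4 (0.04 log units; that floor lies within the scatter)), with no change beyond the scatter expected. For compound 4 the estimated value is 90000 nM, with an expected range from 35000 nM to 200000 nM, and a report of only a limit is quite likely.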

Compound 4, half-maximal inhibitory concentration: > 100000 nM
Compound 4 was reported as a limit (the forecaster's own chance of this, stated with the estimate: 65%); middle value at least 1.1-fold (0.04 log units) away from the limit.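

In this assay, the chain can now be read in both directions from compound 1: hydrogen in place of pentyl, three bonds along the chain from an oxygen on an unsaturated carbon, gives an at least 3.5-fold higher number from compound 1 to compound 4 (0.54 log units; beyond the scatter). The earlier step, an at least 3.5-fold higher number from compound 1 to compound 3 (0.54 log units; beyond the scatter), showed a rise in the number only on lengthening, so among the pyrrolidin-1-yl compounds shown, a shorter and a longer chain both lie on the higher-number side of compound 1. The steps to compound 4 from compound 3 and from compound 2 cannot be read, as both ends of each step are limits, and most of the series sits at a single limit: the limit of > 100000 nM in this assay, at which 3 of the 4 values shown sit.

From the compounds shown here alone, how far the chain can move from that of compound 1 before the number rises stays open, and a hexyl or nonyl chain at the same place would narrow this. Going by these compounds, it is also open whether piperidin-1-yl in place of pyrrolidin-1-yl on the thiocarbonyl carbon of compound 1, or an amine or a carboxylic acid at the end of the chain, would give a readable number.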